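The source may hold more compounds than are shown below. What is called first, only, known or untested is meant among the compounds shown, and "the series" means these compounds.

Measured compounds:
compound 1, `O=C(/C(=C/c1ccc(Cl)cc1)CCl)c1ccccc1`, which in a functional assay on T47D cells (Homo sapiens) for inhibition, read by sulforhodamine B assay, with a stated time of 48 h (on this read-out lower numbers stand for stronger inhibition of growth and higher numbers for weaker inhibition of growth), gives 17000 nM
compound 2, `O=C(/C(=C/c1ccc(Cl)cc1Cl)CCl)c1ccccc1`, which in this assay gives 6300 nM
compound 3, `CC(=O)OC/C(=C/c1ccc(Cl)cc1)C(=O)c1ccc(Cl)cc1`, which in this assay gives 12000 nM

Compound 2 differs from compound 1 by one change, (chloro in place of hydrogen on an aromatic carbon). That change gave a 2.7-fold lower number from compound 1 to compound 2 (0.43 log units; beyond the scatter). Compound 3 has a different core from compound 1; the difference between the two cores is not broken down here, and the two values stand close together.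

Compound 4, `CC(=O)OC/C(=C/c1ccc(Cl)cc1Cl)C(=O)c1ccc(Cl)cc1`, has not yet been measured. It differs from compound 3 by chloro in place of hydrogen on an aromatic carbon, the same change, at the same place, that turned compound 1 into compound 2. Because that earlier change gave a 2.7-fold lower number from compound 1 to compound 2 (0.43 log units; beyond the scatter), a step of about the same size is expected from compound 3 to compound 4 in this assay, namely a 2.7-fold lower number from compound 3 to compound 4 (0.43 log units; beyond the scatter). Compound 4 is therefore estimated at 4500 nM, within a range from 2000 nM to 10000 nM.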

Compound 4, concentration for 50% growth inhibition: 20000 nM
For compound 4 the middle estimate is 4.4-fold (0.65 log units) below the measured one, and the stated range ends below it.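

In this assay, going from 4-chlorophenyl to 2,4-dichlorophenyl on the core of compound 3 gave a 1.7-fold higher number from compound 3 to compound 4 (0.22 log units; within the scatter), so the gain seen on the core of compound 1 did not carry over. In this series, the same change therefore cannot be treated as a fixed step that moves unchanged from one core to the other: the same change on two cores in this assay, a 2.7-fold lower number (0.43 log units; beyond the scatter) from compound 1 to compound 2 and a 1.7-fold higher number (0.22 log units; within the scatter) from compound 3 to compound 4, 4.5-fold (0.65 log units) apart, beyond the scatter of two such steps This rests on a single pair of compounds for each core, so it does not show why the two steps part, or how the change would behave on any other core.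

Going by these compounds, whether a fluoro group, a methoxy group or an amine in the same place would follow either pair remains open. Also open is which part of the difference between the two cores matters, as the compounds shown do not separate it.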